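The source may hold more compounds than are shown below. What is called first, only, known or untested is meant among the compounds shown, and "the series" means these compounds.

Measured compounds:

- Compound 1, `CC1(C)CCC[C@]1(C)c1ccc(C=O)cc1`: 252000 nM
- Compound 2, `C=C1CCC[C@]2(C)CCC(c3cn(-c4ccc(OC)cc4)nn3)=CC[C@@]12C`: 43600 nM

In a functional assay on HeLa cells (Homo sapiens) for cytotoxicity, read by MTT assay, with a stated time of 48 h (on this read-out lower numbers stand for stronger inhibition and higher numbers for weaker inhibition), compound 1 gives 252000 nM, and compound 2 gives 43600 nM, the lower of the two numbers shown; the gap between them is beyond the scatter, but the two structures differ in many places at once, so their values show only that compound 2 is the more strongly inhibiting of the pair.

Compound 3, `C=C1CCC[C@]2(C)CCC(c3cn(-c4ccc(I)cc4)nn3)=CC[C@@]12C`, has not yet been tested in this assay. It is built on the same core as compound 2, and the only difference between them is iodo in place of methoxy on an aromatic carbon.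

Among the measured compounds shown here, no measured pair in this set differs by only this change, so there is nothing here that tells how such an exchange moves the number. Taking compound 2 as the anchor, the step of a 1.5-fold lower number from compound 2 to compound 3 (0.16 log units; within the scatter) that is expected is small, with no clear direction beyond the scatter. On that basis compound 3 is estimated at 30000 nM, with a plausible range from 8000 nM to 120000 nM.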

Compound 3, half-maximal inhibitory concentration: 144000 nM
The estimate for compound 3 lay 4.8-fold (0.68 log units) below the measured number; the measured number lies above the stated range.
By their numbers in this assay, from the lowest: compound 2; then compounds 3 and 1 (each within the scatter of the next).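

In this assay, replacing the 4-methoxyphenyl group with the 4-iodophenyl group gives a 3.3-fold higher number from compound 2 to compound 3 (0.52 log units; beyond the scatter), so inhibition weakens modestly but beyond the scatter. Compound 1 and compound 2 differ in many places, so their gap could not be tied to any one part of the structure, whereas this pair differs at a single place: the aromatic carbon para to a large group. The group on this carbon therefore affects the read-out, and of the two groups compared, methoxy gives the stronger inhibition, but no measurement here explains the shift.

With only methoxy and iodo to compare at this carbon, two groups cannot show whether the trend follows any feature of the group or is specific to this pair. Compounds carrying an amine, a carboxylic acid, a fluoro group or a longer ether such as ethoxy at the same place on the shared core would show how far the number can move in either direction.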